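Compound 4: a new amide side chain on compound 3

A few compounds are considered here, and "the series" means these few. Any claim that something is new, unique, unknown or untested is made for them only; others in the source may bear on it.

In an ADME assay on L02 cells (Homo sapiens) for cytotoxicity, read by MTT assay, with a stated time of 48 h (a lower number here means a stronger inhibitor, a higher number a weaker inhibitor), compound 1 (`CCN(CC)CCNC(=O)c1ccc(C(CC)(CC)c2ccc(OCC(=O)C(C)(C)C)c(C)c2)n1CC`) gives 2500 nM and compound 2 (`CCn1c(C(=O)NCCN(C)C)ccc1C(CC)(CC)c1ccc(OCC(=O)C(C)(C)C)c(C)c1`) gives 2500 nM. Compound 3 (`CCn1c(C(=O)NCC(OC)OC)ccc1C(CC)(CC)c1ccc(OCC(O)C(C)(C)C)c(C)c1`) gives 22200 nM, the highest of the three numbers and beyond the scatter from both other compounds.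

The next compound to be read is compound 4 (`CCn1c(C(=O)N(C)CC(=O)O)ccc1C(CC)(CC)c1ccc(OCC(O)C(C)(C)C)c(C)c1`). Relative to compound 3, the change is (carboxymethyl)(methyl)amino in place of (2,2-dimethoxyethyl)amino on a carbonyl carbon. Cut one bond further out, this reads as (2,2-dimethoxyethyl)carbamoyl to (carboxymethyl)(methyl)carbamoyl.

Among the measured compounds shown here, only one measured step bears on this change, and only loosely. no change at the digits printed from compound 1 to compound 2 (within the scatter), with dimethylamino in place of diethylamino on a saturated chain carbon, two bonds along the chain from an amide-type nitrogen. For the measured compounds named here, that swap is much narrower than the one made here, and no measured compound carries the entering group. It therefore gives no basis for a direction in this assay, and no step beyond the scatter is expected, although the uncertainty is wide.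

The expected change is a 1.1-fold higher number from compound 3 to compound 4 (0.05 log units; within the scatter).

Compound 4 is estimated at 25000 nM, with an expected range of 9000 nM to 70000 nM.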

Compound 4, half-maximal inhibitory concentration: 32600 nM
Estimate against measurement, compound 4: 1.3-fold (0.12 log units) below, within the range that was stated.
By their numbers in this assay, from the lowest: compounds 1 and 2 (each within the scatter of the next); then compounds 3 and 4 (each within the scatter of the next).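

In this assay, the (2,2-dimethoxyethyl)amino and (carboxymethyl)(methyl)amino groups on a carbonyl carbon are not separated: a 1.5-fold higher number from compound 3 to compound 4 (0.17 log units; within the scatter). This extends the earlier reading, no change at the digits printed from compound 1 to compound 2 (within the scatter), which covered only a swap of dimethylamino for diethylamino on a saturated chain carbon, to a much larger exchange in which the whole group on the carbonyl carbon differs while the rest of the molecule stays the same. No information on the cause of this outcome is available for this series.

The exchange alters the end of the chain and the substitution on the nitrogen together, so the compounds shown do not tell whether either alteration alone would leave the number where it is, or whether the two offset each other. Also open, from the compounds shown here alone, is how a (carboxymethyl)amino group without the methyl, a longer chain ending in a carboxylic acid, or a morpholine ring on the same carbonyl carbon would read against compound 3 and compound 4.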